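Carbamate Nitrogen Substituent Changes in a Small Series

The source may report more compounds than this note shows. Statements on the series, on what has been measured and on what is new or still open speak of the compounds shown alone.

Compound 1 `CCN(C(=O)OC)c1c(N)nc(-c2nn(Cc3ccccc3F)c3ncccc23)nc1N` gives 0.2 uM in an assay on cells for activation of Guanylate cyclase soluble subunit alpha-1 (Rattus norvegicus), read by cGMP accumulation and immunoassay, with a stated time of 10 min; on this read-out higher numbers stand for an effect only at larger amounts of compound and lower numbers for an effect already at smaller amounts. Compound 2 `COC(=O)N(Cc1ccccc1F)c1c(N)nc(-c2nn(Cc3ccccc3F)c3ncccc23)nc1N` gives 0.1 uM and compound 3 `COC(=O)N(Cc1cccc(F)c1)c1c(N)nc(-c2nn(Cc3ccccc3F)c3ncccc23)nc1N` gives 0.2 uM, so compound 1 sits level with compound 3 at the highest of the three numbers, while a 2.0-fold lower number from compound 1 to compound 2 (0.30 log units; within the scatter), no change at the digits printed from compound 1 to compound 3 (within the scatter) and a 2.0-fold higher number from compound 2 to compound 3 (0.30 log units; within the scatter) all fall within the scatter. Compound 4 `Nc1nc(-c2nn(Cc3ccccc3F)c3ncccc23)nc(N)c1NC(=O)OC1CCC1` differs from compound 1 by (cyclobutyloxycarbonyl)amino in place of ethyl(methoxycarbonyl)amino on an aromatic carbon. Every measured step changes the group on the saturated chain carbon bound to the amide-type nitrogen and leaves the methoxycarbonyl untouched, so none bears directly on this change; they show only that this position tolerates variation without movement beyond the scatter. For compound 4 the expectation is therefore no step beyond the scatter, no change at the digits printed from compound 1 to compound 4 (within the scatter), with an estimated value of 0.2 uM and a range from 0.05 uM to 0.8 uM.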

Compound 4, minimum effective concentration: 0.2 uM
Beside the measured number, compound 4's estimate shows no gap at the digits printed; measured number inside the range.
By their numbers in this assay, from the lowest: compounds 2, 1, 3 and 4 (each within the scatter of the next).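

With the ethyl gone from the nitrogen, the amide hydrogen present and cyclobutyloxy in place of methoxy, this assay shows no change at the digits printed from compound 1 to compound 4 (within the scatter) at this aromatic carbon. The change therefore reaches the carbamate itself, not only the group on its nitrogen, and the ethyl is not required for a value within the scatter of compound 1. Nothing available here explains this result.

The loss of the ethyl and the gain of the cyclobutyloxy come in one step and cannot be separated. Going by these compounds, a carboxylic acid or a plain amine in place of the carbamate remains open.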